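A few compounds are considered here, and "the series" means these few. Any claim that something is new, unique, unknown or untested is made for them only; others in the source may bear on it.

Of the compounds shown here, three sharing one core have been measured in a functional assay on MGC-803 cells (Homo sapiens) for antiproliferative activity, read by CCK-8 assay, with a stated time of 72 h, tested at 2 uM; a lower number here means a weaker effect, a higher number a stronger effect of the compound at the concentration tested. Compound 1 `Nc1ccccc1NC(=O)c1ccc(CSC(=S)N2CCc3cc([N+](=O)[O-])ccc32)cc1` gives 26.8%. Compound 2 `Nc1ccccc1NC(=O)c1ccc(CSC(=S)N2CCN(c3ccncc3)CC2)cc1` gives 64.8%. Compound 3 `Nc1ccccc1NC(=O)c1ccc(CSC(=S)N2CCCC2)cc1` gives 27%. Among these three numbers compound 2 stands highest, and its gap to compound 3 and to compound 1 lies beyond the scatter in both cases, so compound 2 is the strongest of the three measured here.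

Compound 4 `Cc1ccc(N2CCN(C(=S)SCc3ccc(C(=O)Nc4ccccc4N)cc3)CC2)cc1` has not yet been measured. It differs from compound 2 in one place: 4-methylphenyl in place of pyridin-4-yl on an amine nitrogen in a ring. The piperazine ring and everything on the other side of the core are unchanged, and the hydrogen-bond acceptor of the pyridine ring leaves with it.

Within the data shown here, no pair of measured compounds differs in one place only, so no measured step can guide the size of this change. Compound 1 and compound 3, which carry other groups at the thiocarbamate nitrogen, both sit far below compound 2, but neither of them is a one-place change from compound 2 or from compound 4. The expected step from compound 2 to compound 4 in this assay is therefore uncertain, and a moderate fall is expected, a number 14.8 percentage points lower from compound 2 to compound 4 (beyond the scatter). In this assay compound 4 is estimated at 50%, with a range from 25% to 75%.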

Compound 4, a percentage reported as inhibition, at one concentration (the size of the read-out at that concentration, not a potency): 33.4%
Compound 4: the middle estimate sits 16.6 percentage points above what was measured, within the range that was stated.
By their numbers in this assay, from the lowest: compounds 1, 3 and 4 (each within the scatter of the next); then compound 2.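

Among these compounds, the first one-place change at this position shows that the group on the ring amine nitrogen strongly affects the result in this assay: 4-methylphenyl in place of pyridin-4-yl gives a number 31.4 percentage points lower from compound 2 to compound 4 (beyond the scatter) on this read-out. Keeping a six-membered aromatic ring at this place is therefore not enough to preserve the effect seen with compound 2. The swap removes the ring nitrogen with its hydrogen-bond acceptor and also adds a methyl group, and no information here on any property of these compounds accounts for the drop.

A plain phenyl group at this place would help separate the two parts of the change, showing whether the loss follows the missing ring nitrogen or the added methyl group. Pyridin-3-yl and pyridin-2-yl would go further, asking whether the ring nitrogen must sit where it does in compound 2 or whether a nitrogen anywhere in this ring gives a similar result.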